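Swapping a cyclopropylfuran for a pyridine on a shared core

This account rests on a few compounds, and the source may have more. Where it says the series, first, only, none or still open, it means among the compounds named here.

Of the compounds shown here, three built on one shared core have been measured in a functional assay on CHO-K1 cells for antagonist activity at adenosine receptor A1 (Homo sapiens), read by a beta-galactosidase reporter and cAMP accumulation, with stated times of 15 min and 6 h; on this read-out higher numbers stand for weaker inhibition and lower numbers for stronger inhibition. Compound 1 `Cc1ccc(-c2nc(N)c3ccsc3n2)o1` gives 493 nM. Compound 2 `Nc1nc(-c2ccc(C3CC3)o2)nc2sc(Cc3ccccc3)cc12` gives 861 nM, the highest of the three numbers; its gap to compound 1 lies within the scatter, whereas compound 3 `COc1ccccc1Cc1cc2c(N)nc(-c3cccc(C#N)c3)nc2s1` gives 129 nM, which stands beyond the scatter from compound 2. Compound 4 `Nc1nc(-c2cccnc2)nc2sc(Cc3ccccc3)cc12` has not yet been measured. It differs from compound 2 in one place: pyridin-3-yl in place of 5-cyclopropylfuran-2-yl on an aromatic carbon. Among the compounds with values here, no pair of measured compounds isolates this change, so the expectation rests only on the spread seen so far. The step of a 1.9-fold lower number from compound 2 to compound 4 (0.28 log units; within the scatter) is expected to be small, toward a lower number, and quite possibly within the scatter. Compound 4 is expected to give about 450 nM, within a range from 120 nM to 1700 nM.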

Compound 4, inhibition constant: 1420 nM
Compound 4: middle estimate off by 3.2-fold (0.50 log units), on the low side; the measured number falls inside the stated range.
By their numbers in this assay, from the lowest: compound 3; then compounds 1, 2 and 4 (each within the scatter of the next, the first and the last beyond it).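

In this assay, within the data shown here, pyridin-3-yl in place of 5-cyclopropylfuran-2-yl on this aromatic carbon gives a 1.6-fold higher number from compound 2 to compound 4 (0.22 log units; within the scatter) and is the first change at this position isolated by a measured pair. A six-membered aromatic ring here replaces a five-membered aromatic ring carrying a three-membered ring, and the read-out does not separate the two. No measurement at hand explains this result.

On these data alone, whether an amine or a carboxylic acid at this position would shift the number beyond the scatter stays open. So does whether the same swap would behave alike with a different group elsewhere on the shared core.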